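Bromo on the Phenyl Ring: Expectation from Two Limits

This account rests on a few compounds, and the source may have more. Where it says the series, first, only, none or still open, it means among the compounds named here.

Compound 1 `CN(C)C/C=C(/c1ccccc1)c1cccnc1`: 107 umol/kg
Compound 2 `CN(C)C/C=C(/c1ccc(I)cc1)c1cccnc1`: > 88 umol/kg, a limit
Compound 3 `Cc1ccc(/C(=C/CN(C)C)c2cccnc2)cc1`: > 117 umol/kg, a limit

Going by the values given here, in an in vivo functional assay on the whole organism (brain) for inhibition of Norepinephrine transporter (Rattus norvegicus) (on this read-out lower numbers stand for an effect already at smaller amounts and higher numbers for an effect only at larger amounts of compound), compound 1 gives 107 umol/kg, the only plain number among the three values. Compound 2 reaches only a limit of the assay, and so does compound 3. Compound 4 `CN(C)C/C=C(\c1cccnc1)c1ccccc1Br` differs from compound 1 by bromo in place of hydrogen on an aromatic carbon. Among the compounds with values here, two measured steps bear on this change, both placing a group on an aromatic carbon of the same ring: a step that the limit leaves unreadable from compound 1 to compound 2 and an at least 1.0-fold higher number from compound 1 to compound 3 (0.03 log units; that floor lies within the scatter). Neither yields a readable size, and both substituted compounds reach only a limit. Compound 4 is therefore expected to show a 1.5-fold higher number from compound 1 to compound 4 (0.17 log units; within the scatter), with a fair chance of again returning a limit. The estimate for compound 4 is 160 umol/kg, within 60 umol/kg to 450 umol/kg.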

Compound 4, dose for half-maximal effect: 37 umol/kg
Compound 4: middle estimate off by 4.3-fold (0.64 log units), on the high side, and the stated range ends above it.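

In this assay, going by these compounds alone, bromo ortho to a large group gives the first readable step on this ring: a 2.9-fold lower number from compound 1 to compound 4 (0.46 log units; beyond the scatter). The steps to compound 2 and compound 3 cannot be read, as both compounds return only limits of the assay, so compound 4 alone shows that a group on this ring can go with an effect at a smaller dose. Nothing shown gives a cause for this step.

From the compounds shown here alone, whether chloro, fluoro or an amine on the same carbon would give a similar step remains open. Going by these compounds, it is also open whether methyl there would behave as bromo does.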